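Weak Phthalimide Sulfonamides and a Dichlorobenzyl Variant

A few compounds are considered here, and "the series" means these few. Any claim that something is new, unique, unknown or untested is made for them only; others in the source may bear on it.

Compound 1 `Cc1ccc(S(=O)(=O)Nc2ccc3c(c2)C(=O)N(C)C3=O)cc1` reaches only a limit in an assay on isolated protein for inhibition of lactase/phlorizin hydrolase (Rattus norvegicus), read by colorimetric assay (on this read-out higher numbers stand for weaker inhibition and lower numbers for stronger inhibition), > 200000 nM. Compound 2 `Cc1ccc(S(=O)(=O)Nc2ccc3c(c2)C(=O)N(Cc2ccccc2F)C3=O)cc1` gives 180000 nM in this assay, the only number shown. For the measured compounds named here, the sole measured step, an at least 1.1-fold lower number from compound 1 to compound 2 (0.04 log units; that floor lies within the scatter), rests on the floor set by the limit of > 200000 nM in this assay, at which 1 of the 2 values shown sits. Compound 3 `Cc1ccc(S(=O)(=O)Nc2ccc3c(c2)C(=O)N(Cc2ccc(Cl)c(Cl)c2)C3=O)cc1` carries 3,4-dichlorophenyl in place of 2-fluorophenyl on a saturated chain carbon bound to an amide-type nitrogen in a ring. Since an at least 1.1-fold lower number from compound 1 to compound 2 (0.04 log units; that floor lies within the scatter) stays within the scatter, compound 3 is expected to show a 1.2-fold lower number from compound 2 to compound 3 (0.08 log units; within the scatter), with no direction beyond the scatter. Compound 3 is estimated at 150000 nM, between 50000 nM and 400000 nM.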

Compound 3, half-maximal inhibitory concentration: 101000 nM
Compound 3: middle estimate off by 1.5-fold (0.17 log units), on the high side; the range from low to high includes it.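

In this assay, 3,4-dichlorophenyl in place of 2-fluorophenyl on this saturated chain carbon gives a 1.8-fold lower number from compound 2 to compound 3 (0.25 log units; within the scatter), so two differently halogenated aryl groups at this position do not separate. Even set against the hydrogen of compound 1, the dichlorinated group gives only an at least 1.9-fold lower number from compound 1 to compound 3 (0.29 log units; that floor lies within the scatter). That comparison offers a floor and not a measured size, since it rests on a limit: the limit of > 200000 nM in this assay, at which 1 of the 3 values shown sits.

The compounds shown leave open whether an amine, a carboxylic acid or a longer chain at this position would give a step beyond the scatter.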